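Swapping an Aryl Carbonyl for a Short Chain

The source may hold more compounds than are shown below. What is called first, only, known or untested is meant among the compounds shown, and "the series" means these compounds.

Compound 2 `CC1=NN(C(=O)c2ccc(C)cc2)C(c2cc(Br)cc(Br)c2O)C1` and compound 1 `CCC(=O)N1N=C(C)CC1c1cc(Br)cc(Br)c1O` share one core and differ at a single spot: ethyl in place of 4-methylphenyl on a carbonyl carbon. In a functional assay on PC-3 cells (Homo sapiens) for cytotoxicity, read by MTT assay, with a stated time of 48 h (a higher number here means a weaker inhibitor, a lower number a stronger inhibitor), compound 2 gives 41200 nM, and compound 1 gives 28600 nM, so the change amounted to a 1.4-fold lower number from compound 2 to compound 1 (0.16 log units; within the scatter). Compound 3 `Cc1ccc(C(=O)N2N=C(c3cc4ccccc4oc3=O)CC2c2ccccc2)cc1` is built on a different core, and the difference between the two cores is not broken down here. In this assay compound 3 gives 13200 nM, the lowest number of the three measured compounds, with both other values beyond the scatter. Compound 4 `CCC(=O)N1N=C(c2cc3ccccc3oc2=O)CC1c1ccccc1` arises from compound 3 by the same change that turned compound 2 into compound 1: ethyl in place of 4-methylphenyl on a carbonyl carbon. The expected step in this assay is a 1.2-fold lower number from compound 3 to compound 4 (0.08 log units; within the scatter), and this expectation rests on the earlier outcome of a 1.4-fold lower number from compound 2 to compound 1 (0.16 log units; within the scatter), which stayed within the scatter on a different core. For compound 4 the expected value in this assay is therefore 11000 nM, with a likely range from 5000 nM to 25000 nM.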

Compound 4, half-maximal inhibitory concentration: 4370 nM
Estimate against measurement, compound 4: 2.5-fold (0.40 log units) above; the whole stated range lies above it.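

In this assay the swap of 4-methylphenyl for ethyl on the carbonyl carbon gives a step larger than the usual scatter on this core (a 3.0-fold lower number from compound 3 to compound 4 (0.48 log units; beyond the scatter)), whereas on the other core the same swap stayed within it. Even so, the two steps cannot be told apart, so the data give no sign that the core changes what this swap does: the same change on two cores in this assay, a 1.4-fold lower number (0.16 log units; within the scatter) from compound 2 to compound 1 and a 3.0-fold lower number (0.48 log units; beyond the scatter) from compound 3 to compound 4, 2.1-fold (0.32 log units) apart, within the scatter of two such steps. This does not show that the swap carries over equally, since two cores are a small sample and a real difference of this size could be hidden in the scatter, and the numbers alone do not say why the value changed.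

The compounds shown have only 4-methylphenyl or ethyl at this carbonyl carbon, so it remains open how a longer chain such as butyl, or a chain ending in an amine or a carboxylic acid, would behave there. A third core carrying the same pair of groups would also remain to be seen.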